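A few compounds are considered here, and "the series" means these few. Any claim that something is new, unique, unknown or untested is made for them only; others in the source may bear on it.

Measured so far in a functional assay on MCF7 cells (Homo sapiens) for cytotoxicity, read by MTT assay, with a stated time of 96 h; on this read-out lower numbers stand for stronger inhibition and higher numbers for weaker inhibition
- compound 1 `COc1cc(C(=O)c2cn(-c3cccc(C)c3)cc2-c2ccccc2F)cc(OC)c1OC` gives 190 nM
- compound 2 `COc1cc(C(=O)c2cn(-c3cccc(N)c3)cc2-c2ccccc2F)cc(OC)c1OC` gives 17 nM

Compound 2 holds the lower of the two numbers, and the gap to compound 1 lies beyond the scatter. Compound 3 `COc1cc(C(=O)c2cn(-c3cccc(N)c3)cc2-c2cccc(N)c2)cc(OC)c1OC` is the next to be read. It carries 3-aminophenyl in place of 2-fluorophenyl on an aromatic carbon and otherwise matches compound 2.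

Within the data shown here, one measured step bears on this, only loosely: an 11-fold lower number from compound 1 to compound 2 (1.05 log units; beyond the scatter), a large change with amino in place of methyl on an aromatic carbon. That step altered the other aromatic group, not the one replaced here. Among the measured compounds shown here, no measured step touches the 2-fluorophenyl group, so the data fix neither size nor direction.

A modest move to a higher number is expected, stated as a 2.4-fold higher number from compound 2 to compound 3 (0.37 log units; beyond the scatter) in this assay and held with wide uncertainty. For compound 3 the estimated value is 40 nM, with an expected range from 8 nM to 200 nM overall.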

Compound 3, half-maximal inhibitory concentration: 60 nM
For compound 3 the middle estimate is 1.5-fold (0.18 log units) below the measured one; measured number inside the range.
By their numbers in this assay, from the lowest: compound 2; then compound 3; then compound 1.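

In this assay, among these compounds, 3-aminophenyl in place of 2-fluorophenyl gives a 3.5-fold higher number from compound 2 to compound 3 (0.55 log units; beyond the scatter), the first measured change at this position, and it shows that the group held here shifts the number by more than the scatter. An amino group brought in here does not repeat the direction of an 11-fold lower number from compound 1 to compound 2 (1.05 log units; beyond the scatter), so within these compounds its arrival on the two aromatic groups goes opposite ways, although the present change also removes fluorine. No measurement on hand accounts for the step.

Still open, going by these compounds, is how much of the step follows the loss of fluorine and how much the gain of amino, which a plain phenyl group at this position would help to separate. Also open, on these data alone, is how a methoxy or hydroxyl group on this ring would read.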